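The source may hold more compounds than are shown below. What is called first, only, known or untested is meant among the compounds shown, and "the series" means these compounds.

Compound 1 `CC(=O)OCn1oc(=O)c2ccccc21`: 5.1 ug/mL
Compound 2 `CC(C)(C)C(=O)OCn1oc(=O)c2ccccc21`: 4.2 ug/mL; 16 ug/mL (2 entries)

In a functional assay on L1210 cells (Mus musculus) for cytotoxicity (a lower number here means a stronger inhibitor, a higher number a weaker inhibitor), compound 1 gives 5.1 ug/mL, the only number shown for it, with one further entry that carries no single number. Compound 2 has several entries in this assay (the several entries of compound 2 in this assay, 4.2 ug/mL; 16 ug/mL (2 entries)), and they scatter around the value of compound 1. Compound 3 `Cc1ccc(C(=O)OCn2oc(=O)c3ccccc32)cc1` is not yet measured; it differs from compound 1 thus (4-methylphenyl in place of methyl on a carbonyl carbon). Among the compounds with values here, no step between measured compounds is available. A step in this assay is expected to be small, either way, and probably within the scatter. Compound 3 is expected at 6 ug/mL, between 2 ug/mL and 20 ug/mL, which means a step of a 1.2-fold higher number from compound 1 to compound 3 (0.07 log units; within the scatter) is estimated.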

Compound 3, concentration for 50% inhibition: 4.6 ug/mL
For compound 3 the middle estimate is 1.3-fold (0.12 log units) above the measured one; the range from low to high includes it.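

In this assay, putting 4-methylphenyl in place of methyl on a carbonyl carbon brings a 1.1-fold lower number from compound 1 to compound 3 (0.04 log units; within the scatter). Within the data shown here, this is the first step that can be read at this position, and it shows that a six-membered aromatic ring there keeps the number within the scatter of compound 1. The step is also small beside the spread of repeated entries for a related compound: the several entries of compound 2 in this assay, 4.2 ug/mL; 16 ug/mL (2 entries)

The compounds shown leave open whether an amine or a carboxylic acid on that aromatic ring would move the number beyond the scatter. They also leave open what a longer chain in place of methyl would do.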